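The compounds below may be only part of what the source reports. "The series", "measured", "known", "first", "only" and "open" are said of these compounds alone.

In an assay for inhibition of Tryptophan 2,3-dioxygenase (Homo sapiens), with stated times of 10 min and 60 min (a higher number here means a weaker inhibitor, a lower number a stronger inhibitor), the two measured compounds stand as follows:
compound 1 `FC(F)(F)c1cc(NCC2CNC2)c2cn[nH]c2c1`: > 100000 nM
compound 2 `FC(F)(F)c1cc(NC[C@@H]2CCCCN2)c2cn[nH]c2c1`: 8050 nM

Within the data shown here, compound 2 holds the only actual number in this assay. For compound 1 the value shown is a limit of the assay rather than a number (the limit of > 100000 nM in this assay, at which 1 of the 2 values shown sits). Among the measured compounds shown here, the single measured step, an at least 12-fold lower number from compound 1 to compound 2 (1.09 log units; beyond the scatter), is large and runs toward stronger inhibition.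

Compound 3 `Nc1cccc(CNc2cc(C(F)(F)F)cc3[nH]ncc23)c1` differs from compound 2 by 3-aminophenyl in place of piperidin-2-yl on a saturated chain carbon bound to a nitrogen on an aromatic ring. The measured step exchanged one saturated amine ring for another of a different size, whereas this change replaces the saturated ring with an aromatic one, so it offers only a loose guide. The gain seen in an at least 12-fold lower number from compound 1 to compound 2 (1.09 log units; beyond the scatter) arrived together with the piperidin-2-yl group that now leaves, so a moderate weakening is expected, a 2.2-fold higher number from compound 2 to compound 3 (0.35 log units; beyond the scatter), though with wide uncertainty. Compound 3 is therefore estimated at 18000 nM, within 3500 nM to 90000 nM.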

Compound 3, half-maximal inhibitory concentration: 2510 nM
Compound 3: middle estimate off by 7.2-fold (0.86 log units), on the high side; measured number outside the range, below it.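

In this assay, the change to the aromatic group gives a 3.2-fold lower number from compound 2 to compound 3 (0.51 log units; beyond the scatter), so at this place, on a saturated chain carbon bound to a nitrogen on an aromatic ring, neither a saturated ring nor a defined stereocentre is needed for the activity seen so far, and a six-membered aromatic ring of carbon only does better than piperidin-2-yl. The value of compound 1 is a limit of the assay and not a number: the limit of > 100000 nM in this assay, at which 1 of the 3 values shown sits. Measured against that limit, the widest gap among these compounds is an at least 39-fold lower number from compound 1 to compound 3 (1.60 log units; beyond the scatter).

From the compounds shown here alone, what a plain phenyl ring without the amine would give remains open, so the share of the amine in this gain and the share of the ring cannot be separated. Also open, going by these compounds, is whether a carboxylic acid could take the place of that amine.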